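A Methylsulfonyl Swap at the Cytotoxicity Limit

The source may hold more compounds than are shown below. What is called first, only, known or untested is meant among the compounds shown, and "the series" means these compounds.

Compound 1: `CC(C)N(Cc1cccc(OCCCCCC(=O)O)c1)C(=O)c1ccc(-c2cccc3ccccc23)cc1` — < 1.3 nM
Compound 2: `CC(C)COc1cccc(-c2ccc(C(=O)N(Cc3cccc(OCCCCCC(=O)O)c3)C(C)C)cc2)c1` — > 26000 nM
Compound 3: `CC(C)N(Cc1cccc(OCCCCCC(=O)O)c1)C(=O)c1ccc(-c2cccc(O)c2)cc1` — > 26000 nM

In an ADME assay on BJ cells (Homo sapiens) for cytotoxicity, read by CellTiter-Glo and resazurin assay, with a stated time of 72 h (on this read-out higher numbers stand for an effect only at larger amounts of compound and lower numbers for an effect already at smaller amounts), compound 1 gives < 1.3 nM, which is a limit of the measurement and not a number. Compound 2 gives > 26000 nM, again a limit. Compound 3 gives > 26000 nM, also a limit, so compound 3 stands at the high end together with compound 2 and far from compound 1 (the limit of < 1.3 nM in this assay, at which 1 of the 3 values shown sits, (the limit of > 26000 nM in this assay, at which 2 of the 3 values shown sit)). The steps of an at least 20000-fold higher number from compound 1 to compound 2 (4.30 log units; beyond the scatter) and an at least 20000-fold higher number from compound 1 to compound 3 (4.30 log units; beyond the scatter) show that exchanging naphthalen-1-yl moves the number up strongly; the step that the two limits leave unreadable from compound 2 to compound 3 cannot be read. Compound 4, `CC(C)N(Cc1cccc(OCCCCCC(=O)O)c1)C(=O)c1ccc(-c2cccc(S(C)(=O)=O)c2)cc1`, differs from compound 3 by methylsulfonyl in place of hydroxy on an aromatic carbon. Among the compounds with values here, no measured step covers this exchange, so a step that the limit leaves unreadable from compound 3 to compound 4 is expected, within the scatter. Compound 4 is estimated at 30000 nM, between 6000 nM and 100000 nM.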

Compound 4, half-maximal effective concentration: > 26000 nM
Compound 4 was reported as a limit (the forecaster's own chance of this, stated with the estimate: 70%); the middle value does not contradict the limit.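

In this assay, 3-(methylsulfonyl)phenyl in place of naphthalen-1-yl gives an at least 20000-fold higher number from compound 1 to compound 4 (4.30 log units; beyond the scatter). Methylsulfonyl is thus a third group, after hydroxy and isobutoxy, that leaves the number far from that of compound 1 when it sits meta to a large group. Compound 4 is reported only as a limit, and the steps among compound 2, compound 3 and compound 4 cannot be read: the limit of > 26000 nM in this assay, at which 3 of the 4 values shown sit.

Going by these compounds, how these three compounds truly rank past that limit stays open. So does whether an amine or a nitrile at this place would bring the number back towards that of compound 1.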